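Trifluoromethyl moved on the aryl ether: compound 4

This account rests on a few compounds, and the source may have more. Where it says the series, first, only, none or still open, it means among the compounds named here.

Three analogues share one core and differ only on the aryl ether. In an assay on SH-SY5Y cells for inhibition of Voltage-dependent N-type calcium channel subunit alpha-1B (Homo sapiens), read by FLIPR and calcium flux, with stated times of 600 s and 300 s, in the presence of a further agent that is not named here (on this read-out higher numbers stand for weaker inhibition and lower numbers for stronger inhibition), compound 1 `CN(Cc1ccc(OCCCN)cc1)c1nc2ccc(Oc3ccccc3)cc2s1` gives 49000 nM, compound 2 `CN(Cc1ccc(OCCCN)cc1)c1nc2ccc(Oc3ccc(C(F)(F)F)cc3)cc2s1` gives 283000 nM and compound 3 `CN(Cc1ccc(OCCCN)cc1)c1nc2ccc(Oc3ccc(F)cc3)cc2s1` gives 98000 nM. Compound 3 thus stands second highest of the three, close to compound 1 and further from compound 2; the steps read a 2.0-fold higher number from compound 1 to compound 3 (0.30 log units; within the scatter) and a 2.9-fold lower number from compound 2 to compound 3 (0.46 log units; beyond the scatter).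

Compound 4 `CN(Cc1ccc(OCCCN)cc1)c1nc2ccc(Oc3cccc(C(F)(F)F)c3)cc2s1` is not yet measured in this assay. Its change from compound 3 is 3-(trifluoromethyl)phenyl in place of 4-fluorophenyl on an oxygen on an aromatic ring. For the measured compounds named here, the steps that bear on it are the trifluoromethyl steps, a 5.8-fold higher number from compound 1 to compound 2 (0.76 log units; beyond the scatter) and a 2.9-fold lower number from compound 2 to compound 3 (0.46 log units; beyond the scatter), both toward higher numbers when trifluoromethyl is present; compound 4 carries its trifluoromethyl in the 3-(trifluoromethyl)phenyl group rather than in the ring of compound 2, and no measured pair tells how that matters. A modest step to a higher number is therefore expected for compound 4, a 2.0-fold higher number from compound 3 to compound 4 (0.31 log units; beyond the scatter), because of a 2.9-fold lower number from compound 2 to compound 3 (0.46 log units; beyond the scatter) run in reverse. The estimate for compound 4 is 200000 nM, within 70000 nM to 600000 nM.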

Compound 4, half-maximal inhibitory concentration: 77000 nM
Estimate against measurement, compound 4: 2.6-fold (0.41 log units) above; low and high end bracket the measured number.
By their numbers in this assay, from the lowest: compounds 1, 4 and 3 (each within the scatter of the next); then compound 2.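

In this assay, for the compounds shown here, the place of trifluoromethyl on the aryl ether ring matters: 3-(trifluoromethyl)phenyl in place of 4-(trifluoromethyl)phenyl gives a 3.7-fold lower number from compound 2 to compound 4 (0.57 log units; beyond the scatter), the first measured step between two placements of one group. Compound 4 cannot be separated from its other two neighbours (a 1.6-fold higher number from compound 1 to compound 4 (0.20 log units; within the scatter) and a 1.3-fold lower number from compound 3 to compound 4 (0.10 log units; within the scatter)), so the step of a 5.8-fold higher number from compound 1 to compound 2 (0.76 log units; beyond the scatter) belongs to that one placement and not to trifluoromethyl wherever it stands on the ring. No evidence at hand accounts for the difference between the two placements.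

Open, from the compounds shown here alone, is whether a nitrile or a methoxy group would split in the same way between these two ring placements. Also open, going by these compounds, is whether an amine or a carboxylic acid on this ring would give a number clearly lower than that of compound 1.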